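The source may hold more compounds than are shown below. What is called first, only, known or untested is meant among the compounds shown, and "the series" means these compounds.

Compound 1 `Cc1ccc(SCc2ccc(C(=O)Nc3ccccc3N)cc2)cc1` sits highest of the two numbers in hand: in a functional assay on A-375 cells (Homo sapiens) for inhibition, read by CCK-8 assay, with a stated time of 72 h, tested at 8 uM (on this read-out lower numbers stand for less inhibition of growth and higher numbers for more inhibition of growth at the one concentration tested), compound 1 gives 67%, while compound 2 `CC(C)(C)c1ccc(SCc2ccc(C(=O)Nc3ccccc3N)cc2)cc1` gives 33.1%. Within the data shown here, the one measured step, a number 33.9 percentage points lower from compound 1 to compound 2 (beyond the scatter), shows that enlarging the group on that aromatic ring cost much inhibition. Compound 3 `Cc1cc(C)cc(SCc2ccc(C(=O)Nc3ccccc3N)cc2)c1` differs from compound 1 by 3,5-dimethylphenyl in place of 4-methylphenyl on a sulfur. Among the measured compounds shown here, no measured step covers this exact change, but the single step in hand points toward a loss; a more modest drop, a number 17 percentage points lower from compound 1 to compound 3 (beyond the scatter), is expected. Compound 3 is therefore estimated at 50%, in a range from 25% to 75%.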

Compound 3, percent growth inhibition at one concentration: 74.7%
Compound 3: middle estimate off by 24.7 percentage points, on the low side; measured number inside the range.
By their numbers in this assay, from the lowest: compound 2; then compounds 1 and 3 (each within the scatter of the next).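

Putting 3,5-dimethylphenyl in place of 4-methylphenyl on the sulfur gives a number 7.7 percentage points higher from compound 1 to compound 3 (within the scatter) in this assay, so the two compounds cannot be told apart. A larger group on this sulfur therefore need not cost inhibition: the loss in a number 33.9 percentage points lower from compound 1 to compound 2 (beyond the scatter) does not appear with this two-methyl ring. Nothing available explains why these two changes differ.

Still open, as far as these compounds go, is how a methoxy group, a chlorine atom or an amine on this aromatic ring would compare with the methyl groups of compound 1 and compound 3.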